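The compounds below may be only part of what the source reports. "The series", "measured", "known", "first", "only" and "open" are said of these compounds alone.

Of the compounds shown here, three have been tested so far in a toxicity assay on THP-1 cells (Homo sapiens) for inhibition; a higher number here means that more compound is tolerated, a lower number that less compound is tolerated. Compound 1 `Cc1cccc(C(=O)Nc2ncc(-c3ccccc3)n2C)c1` carries a 3-methylphenyl on a carbonyl carbon; in this assay compound 1 gives > 50000 nM, which is a limit of the assay rather than a number. Compound 2 `Cn1c(-c2ccccc2)cnc1NC(=O)c1ccc(Cl)cc1` has 4-chlorophenyl in that place, and in this assay compound 2 gives > 100000 nM, again a limit. Compound 3 `Cc1ccc(C(=O)Nc2ncc(-c3ccccc3)n2C)cc1` has 4-methylphenyl there, and in this assay compound 3 gives > 50000 nM, also a limit. Compound 1 thus stands only at a limit, as do the other two: the limit of > 50000 nM in this assay, at which 2 of the 3 values shown sit, and (the limit of > 100000 nM in this assay, at which 1 of the 3 values shown sits). The three steps between them, a step that the two limits leave unreadable from compound 1 to compound 2, a step that the two limits leave unreadable from compound 1 to compound 3 and a step that the two limits leave unreadable from compound 2 to compound 3, cannot be sized, since each joins two limits.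

Compound 4 `COc1ccc(-c2cnc(NC(=O)c3cccc(C)c3)n2C)cc1` differs from compound 1 by methoxy in place of hydrogen on an aromatic carbon. Among the compounds with values here, none of the measured steps involves this change, and none of them is readable, so they give no sign of a move in either direction. Compound 4 is therefore expected to stay at a limit of the same kind, with a step that the limit leaves unreadable from compound 1 to compound 4 expected to lie within the scatter. The estimate for compound 4 in this assay is 60000 nM, with a range from 20000 nM to 200000 nM.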

Compound 4, half-maximal cytotoxic concentration: > 100000 nM
Compound 4: no number, only a limit (the forecaster's own chance of this, stated with the estimate: 80%); middle value at least 1.6-fold (0.22 log units) away from the limit.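

In this assay compound 1 and compound 4 both stand at limits of the assay rather than at numbers, so the step between them cannot be read. The compounds shown leave open the concentration at which any of them reaches the half-maximal cytotoxic effect, and whether methoxy in place of hydrogen shifts it in either direction.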